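Methyl in place of methoxy: notes toward compound 3

The compounds below may be only part of what the source reports. "The series", "measured", "known", "first", "only" and "open" are said of these compounds alone.

Two numbers exist so far. In an ADME assay on Vero cells (Chlorocebus sabaeus) for cytotoxicity, read by MTT assay, with a stated time of 72 h (on this read-out higher numbers stand for lower toxicity in this test and lower numbers for higher toxicity in this test), compound 1 (`COc1ccc([C@H](O)COC(=O)/C=C/c2ccccc2)cc1`) gives 33500 nM, and compound 2 (`COc1ccc([C@@H](O)COC(=O)/C=C/c2ccccc2)cc1`) gives 23300 nM. Among the measured compounds shown here, compound 2 therefore stands within the scatter of its only neighbour. The single measured step, a 1.4-fold lower number from compound 1 to compound 2 (0.16 log units; within the scatter), lies within the scatter, and what it tests is narrow, as shown by the fact that compounds 1 and 2 differ only in the configuration as drawn. It says nothing direct about the aromatic substituent.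

Compound 3 (`Cc1ccc([C@@H](O)COC(=O)/C=C/c2ccccc2)cc1`) departs from compound 2 at one place: methyl in place of methoxy on an aromatic carbon. This puts methyl in place of methoxy on an aromatic carbon, para to a large group. For the measured compounds named here, no measured step covers a change of this kind, so the only anchor is compound 2 at 23300 nM. Going by the values given here, with no measured step to suggest a direction, no shift beyond the scatter is expected in this assay. The expected change is a 1.1-fold higher number from compound 2 to compound 3 (0.03 log units; within the scatter), a small step of uncertain direction. For compound 3 the estimate is 25000 nM, with an expected range from 10000 nM to 60000 nM.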

Compound 3, half-maximal cytotoxic concentration: > 200000 nM
Compound 3: a limit, no number; the forecaster's own chance of this, stated with the estimate: 10%; middle value at least 8.0-fold (0.90 log units) from the limit.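

In this assay compound 3 gives > 200000 nM, which is a limit of the assay and not a number. Among the compounds shown here, the step of an at least 8.5-fold higher number from compound 2 to compound 3 (0.93 log units; beyond the scatter) is the first to lie beyond the scatter, and it shows that exchanging methoxy for methyl on an aromatic carbon, para to a large group, can move this read-out towards lower toxicity in this test. The earlier step within the scatter could not show this, as the methoxy group stayed in place across it: the fact that compounds 1 and 2 differ only in the configuration as drawn

On these data alone, the true size of the step stays open, and its printed size is only a minimum: the limit of > 200000 nM in this assay, at which 1 of the 3 values shown sits. Also open is whether an ethoxy group, a hydroxyl group or an amine on the same aromatic carbon would leave the number near that of compound 2 or move it as methyl does, and whether methyl would produce a similar step in the opposite configuration, that of compound 1.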